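An Acid in Place of an Ester on Compound 3

The source may report more compounds than this note shows. Statements on the series, on what has been measured and on what is new or still open speak of the compounds shown alone.

Compound 1 `O=S(=O)(/C=C/c1ccccc1)Nc1ccccc1` gives 10000 nM in a functional assay on DU-145 cells (Homo sapiens) for cytotoxicity, read by trypan blue exclusion, with a stated time of 96 h (a lower number here means a stronger inhibitor, a higher number a weaker inhibitor), and compound 2 `COc1ccc(/C=C/S(=O)(=O)Nc2c(F)c(F)c(F)c(F)c2F)cc1N` gives 35000 nM. Compound 3 `COC(=O)CNc1cc(NS(=O)(=O)/C=C/c2c(OC)cc(OC)cc2OC)ccc1OC` gives 350 nM, the lowest of the three numbers; its gaps to compound 1 and to compound 2 both lie beyond the scatter of this assay. Compound 4 `COc1cc(OC)c(/C=C/S(=O)(=O)Nc2ccc(OC)c(NC(C)(C)C(=O)O)c2)c(OC)c1` has not yet been measured. It differs from compound 3 in one place: 1-carboxy-1-methylethyl in place of (methoxycarbonyl)methyl on a nitrogen on an aromatic ring. Among the measured compounds shown here, no measured pair shows this change, so its effect is unknown from these data. Compound 4 is expected to give a somewhat higher number, a 2.3-fold higher number from compound 3 to compound 4 (0.36 log units; beyond the scatter), though a change within the scatter cannot be excluded. Compound 4 is estimated at 800 nM, with a likely range from 250 nM to 2500 nM.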

Compound 4, half-maximal inhibitory concentration: 70 nM
The estimate for compound 4 lay 11-fold (1.06 log units) above the measured number, and the stated range ends above it.
By their numbers in this assay, from the lowest: compound 4; then compound 3; then compound 1; then compound 2.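

In this assay, the exchange of (methoxycarbonyl)methyl for 1-carboxy-1-methylethyl on a nitrogen on an aromatic ring gives a 5.0-fold lower number from compound 3 to compound 4 (0.70 log units; beyond the scatter) and shows that this position can carry a carboxylic acid without a loss in this read-out. The change is a double one, since the ester gives way to an acid and the carbon on the nitrogen gains methyl groups. No measurement on hand gives a reason for the step. The compounds shown leave open whether the acid or the methyl branching accounts for it. Carboxymethyl, or the methyl ester of 1-carboxy-1-methylethyl, on the same nitrogen would separate the two.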